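This account rests on a few compounds, and the source may have more. Where it says the series, first, only, none or still open, it means among the compounds named here.

Measured so far in a functional assay for inhibition of sodium/hydrogen exchanger (Oryctolagus cuniculus); on this read-out lower numbers stand for stronger inhibition and higher numbers for weaker inhibition:
compound 1 `Cc1cc(F)c(S(C)(=O)=O)cc1C(=O)N=C(N)N` — 44 nM
compound 2 `Cc1cc(Sc2ccccc2Cl)c(S(C)(=O)=O)cc1C(=O)N=C(N)N` — 14 nM
compound 3 `Cc1cc(Oc2ccccc2)c(S(C)(=O)=O)cc1C(=O)N=C(N)N` — 10 nM

Compound 3 shows the lowest number of the three in this assay; its gap to compound 2 is within the scatter, so no order between those two is claimed, whereas the step of a 4.4-fold lower number from compound 1 to compound 3 (0.64 log units; beyond the scatter) lies beyond it. Compound 4 `Cc1cc(N2CCCCC2)c(S(C)(=O)=O)cc1C(=O)N=C(N)N` is the next compound; the change is piperidin-1-yl in place of phenoxy on an aromatic carbon. Among the compounds with values here, no measured step swaps one ring-bearing group for another of this kind. Within the data shown here, the steps that bear on this position are a 3.1-fold lower number from compound 1 to compound 2 (0.50 log units; beyond the scatter) and a 4.4-fold lower number from compound 1 to compound 3 (0.64 log units; beyond the scatter), both modest and both toward lower numbers, and a 1.4-fold lower number from compound 2 to compound 3 (0.15 log units; within the scatter), within the scatter. A step near the scatter is therefore expected in this assay, a 2.0-fold higher number from compound 3 to compound 4 (0.30 log units; within the scatter), with no firm direction. Compound 4 is estimated at 20 nM, range 6 nM to 70 nM.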

Compound 4, half-maximal inhibitory concentration: 21 nM
Estimate against measurement, compound 4: 1.1-fold (0.02 log units) below; measured number inside the range.
By their numbers in this assay, from the lowest: compounds 3, 2 and 4 (each within the scatter of the next, the first and the last beyond it); then compound 1.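

In this assay, a non-aromatic ring joined through nitrogen still sits on the lower side of fluoro (a 2.1-fold lower number from compound 1 to compound 4 (0.32 log units; beyond the scatter)), so an aromatic ring in this substituent is not required for that gain. Within the data shown here, the swap from phenoxy is the first ring-for-ring change to exceed the scatter (a 2.1-fold higher number from compound 3 to compound 4 (0.32 log units; beyond the scatter)), while no order is claimed against the (2-chlorophenyl)sulfanyl compound (a 1.5-fold higher number from compound 2 to compound 4 (0.18 log units; within the scatter)). No available data give a reason for these steps.

Open, on these data alone, is whether morpholin-4-yl or an open-chain amine such as diethylamino at this carbon would track compound 4 or compound 3.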